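A few compounds are considered here, and "the series" means these few. Any claim that something is new, unique, unknown or untested is made for them only; others in the source may bear on it.

Compound 1, `C#Cc1cn([C@@H]2O[C@H](CO)[C@@H](O)[C@H]2O)c2ncnc(OC)c12`: 4060 nM. Compound 2, `COc1nc(N)nc2c1c(-c1ccccc1)cn2[C@@H]1O[C@H](CO)[C@@H](O)[C@H]1O`: a limit of the assay, > 20000 nM. Compound 3, `O=c1[nH]cnc2c1c(-c1cc3ccccc3o1)cn2[C@@H]1O[C@H](CO)[C@@H](O)[C@H]1O`: a limit of the assay, > 20000 nM.

Of the compounds shown here, three have been measured in a functional assay on HCT-116 cells (Homo sapiens), read by MTT assay, with a stated time of 72 h; a lower number here means a stronger inhibitor, a higher number a weaker inhibitor. Going by the values given here, compound 1 is the only one with a number. For compound 3 the value is a limit of the assay and not a number, at the limit of > 20000 nM in this assay, at which 2 of the 3 values shown sit. Compound 3 therefore stands at the weak end of what is shown, with no measurable inhibition.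

Compound 4, `O=c1[nH]cnc2c1c(-c1ccoc1)cn2[C@@H]1O[C@H](CO)[C@@H](O)[C@H]1O`, differs from compound 3 by furan-3-yl in place of 1-benzofuran-2-yl on an aromatic carbon. Among the compounds with values here, no step between measured compounds is available to guide this change. The step of a number no higher from compound 3 to compound 4 (the limit leaves the size open) is expected to be small, possibly no more than the scatter. Compound 4 is expected to give about 20000 nM in this assay, within a range of 3000 nM to 60000 nM.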

Compound 4, half-maximal inhibitory concentration: 10300 nM
For compound 4 the middle estimate is 1.9-fold (0.29 log units) above the measured one, within the range that was stated.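

Compound 3 carries a limit of the assay and not a number: the limit of > 20000 nM in this assay, at which 2 of the 4 values shown sit. In this assay, this aromatic carbon, two ring bonds from the ring nitrogen, now has its first step, an at least 1.9-fold lower number from compound 3 to compound 4 (0.28 log units; that floor lies within the scatter), with furan-3-yl in place of 1-benzofuran-2-yl. As far as these compounds go, the change turns a limit into a measured number, but the true size of the step stays unknown.

The compounds shown leave open how an amine or a carboxylic acid on this carbon would read, and whether furan-2-yl would read like furan-3-yl.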